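This account rests on a few compounds, and the source may have more. Where it says the series, first, only, none or still open, it means among the compounds named here.

Of the compounds shown here, three built on one shared core have been measured in a functional assay, with a stated time of 90 s; on this read-out lower numbers stand for stronger inhibition and higher numbers for weaker inhibition. Compound 1 `Cc1nc2c3ccccc3ccc2c2nc3c(ccc4ccccc43)c(-c3cccnc3)c12` gives 156 ug/mL, compound 2 `Cc1nc2c3ccccc3ccc2c2nc3c(ccc4ccccc43)c(-c3cccc4ccccc34)c12` gives 179 ug/mL, and compound 3 `Cc1nc2c3ccccc3ccc2c2nc3c(ccc4ccccc43)c(-c3ccccc3S)c12` gives 158 ug/mL, which places compound 3 second highest of the three numbers, though within the scatter of both others. Compound 4 `Cc1ccc(-c2c3ccc4ccccc4c3nc3c2c(C)nc2c4ccccc4ccc32)cc1` differs from compound 3 by 4-methylphenyl in place of 2-sulfanylphenyl on an aromatic carbon. For the measured compounds named here, every measured step so far exchanges the same aromatic group at that position: a 1.1-fold higher number from compound 1 to compound 2 (0.06 log units; within the scatter), a 1.0-fold higher number from compound 1 to compound 3 (0.01 log units; within the scatter) and a 1.1-fold lower number from compound 2 to compound 3 (0.05 log units; within the scatter), each within the scatter. On that basis no step beyond the scatter is expected for compound 4 in this assay, a 1.0-fold higher number from compound 3 to compound 4 (0.01 log units; within the scatter). Compound 4 is therefore estimated at 160 ug/mL, with a range from 100 ug/mL to 260 ug/mL.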

Compound 4, half-maximal inhibitory concentration: 192 ug/mL
Compound 4: the middle estimate sits 1.2-fold (0.08 log units) below what was measured, within the range that was stated.
By their numbers in this assay, from the lowest: compounds 1, 3, 2 and 4 (each within the scatter of the next).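

In this assay, 4-methylphenyl in place of 2-sulfanylphenyl gives a 1.2-fold higher number from compound 3 to compound 4 (0.08 log units; within the scatter) on this aromatic carbon, so a group with 0 hydrogen-bond donors and 0 hydrogen-bond acceptors sits within the scatter of one with 1 of each. Against the other two groups the picture is the same, with a 1.1-fold higher number from compound 2 to compound 4 (0.03 log units; within the scatter) and a 1.2-fold higher number from compound 1 to compound 4 (0.09 log units; within the scatter) as the remaining steps. No supporting data explain these small differences.

On these data alone, whether an amine, a carboxylic acid or a longer alkyl chain at this carbon would move the number beyond the scatter stays open. The compounds shown also leave open whether changes elsewhere on the shared core would do so.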